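This account rests on a few compounds, and the source may have more. Where it says the series, first, only, none or still open, it means among the compounds named here.

Among the compounds with values here, compound 1 `O=C(CSc1nnc(-c2ccncc2)o1)N/N=C/c1ccc(O)cc1` is the stronger of the two compounds measured so far: in a functional assay on BGC-823 cells (Homo sapiens) for cytotoxicity, read by MTT assay, with a stated time of 48 h (a higher number here means a weaker inhibitor, a lower number a stronger inhibitor), compound 1 gives 7940 nM, while compound 2 `O=C(CSc1nnc(-c2ccncc2)o1)N/N=C/c1cccs1` gives 26700 nM, a step of a 3.4-fold higher number from compound 1 to compound 2 (0.53 log units; beyond the scatter). Compound 3 `O=C(CSc1nnc(-c2ccncc2)o1)N/N=C/C=C/c1ccccc1` carries the change (2-phenylethenyl in place of 4-hydroxyphenyl on a carbon with a double bond to nitrogen). Within the data shown here, the only measured step that bears on this is the one from compound 1 to compound 2, where swapping out the 4-hydroxyphenyl group already weakened the inhibitor, so a further swap to a group lacking any donor or acceptor is expected to weaken it too. Compound 3 is therefore expected at 20000 nM, between 6000 nM and 60000 nM, a step of a 2.5-fold higher number from compound 1 to compound 3 (0.40 log units; beyond the scatter) that is expected.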

Compound 3, half-maximal inhibitory concentration: 10600 nM
Beside the measured number, compound 3's estimate is 1.9-fold (0.28 log units) above it; the measured number falls inside the stated range.
By their numbers in this assay, from the lowest: compounds 1 and 3 (each within the scatter of the next); then compound 2.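

In this assay, 2-phenylethenyl has 0 hydrogen-bond donors and 0 hydrogen-bond acceptors, yet putting it in place of 4-hydroxyphenyl gives a 1.3-fold higher number from compound 1 to compound 3 (0.13 log units; within the scatter), so losing the hydroxyl group from this position does not by itself weaken the compound. Putting 2-phenylethenyl in place of thiophen-2-yl gives a 2.5-fold lower number from compound 2 to compound 3 (0.40 log units; beyond the scatter), which shows that swapping out 4-hydroxyphenyl does not always weaken the compound. No available evidence explains these differences. As far as these compounds go, what an amine or a carboxylic acid on this carbon would give remains open, as does the effect of a saturated 2-phenylethyl chain in place of 2-phenylethenyl.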